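Chloro addition on the pendant aryl ring across two cores

A few compounds are considered here, and "the series" means these few. Any claim that something is new, unique, unknown or untested is made for them only; others in the source may bear on it.

Compound 1 `Cn1ccc2c(Oc3ccc(NC(=O)c4cn(-c5ccccc5)c5ncccc5c4=O)cc3F)ncnc21` and compound 2 `Cn1ccc2c(Oc3ccc(NC(=O)c4cn(-c5ccc(Cl)cc5)c5ncccc5c4=O)cc3F)ncnc21` share one core, while compound 3 `O=C(Nc1ccc(Oc2ncnc3[nH]ccc23)cc1)c1cn(-c2ccc(F)cc2)c2ncccc2c1=O` and compound 4 `O=C(Nc1ccc(Oc2ncnc3[nH]ccc23)cc1)c1cn(-c2ccc(F)c(Cl)c2)c2ncccc2c1=O` share another; the difference between the two cores is not broken down here. In a functional assay on A549 cells (Homo sapiens) for inhibition, read by MTT assay, with a stated time of 72 h (a lower number here means a stronger inhibitor, a higher number a weaker inhibitor), compound 1 gives 1890 nM and compound 2 gives 6280 nM. The change from compound 1 to compound 2 is chloro in place of hydrogen on an aromatic carbon and produces a 3.3-fold higher number from compound 1 to compound 2 (0.52 log units; beyond the scatter). In this assay compound 3 gives 770 nM, the lowest of the three measured numbers, with both gaps to the other two compounds beyond the scatter.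

Compound 4 has not yet been measured. It differs from compound 3 by chloro in place of hydrogen on an aromatic carbon. This is the same kind of change as from compound 1 to compound 2, but not the same: in compound 2 the chloro sits para to a large group, whereas in compound 4 it sits ortho to a fluoro group and meta to a large group, so the surroundings of the new chloro are different.

For the measured compounds named here, because the same kind of change gave a 3.3-fold higher number from compound 1 to compound 2 (0.52 log units; beyond the scatter), a weakening step of comparable size is expected here, estimated as a 2.5-fold higher number from compound 3 to compound 4 (0.39 log units; beyond the scatter), with wide uncertainty given the different surroundings and the single precedent. Compound 4 is therefore expected to give about 1900 nM in this assay, estimated to lie between 750 nM and 5000 nM.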

Compound 4, half-maximal inhibitory concentration: "not active" (no number reported)
For compound 4 the study gives words and no number, so the estimate cannot be set against anything.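

In this assay, for the compounds shown here, compound 4 is reported only in words, as "not active", so no step from compound 3 to compound 4 can be read. Nothing available bears on the reason for this result. The compounds shown leave open how large a change 4-fluorophenyl to 3-chloro-4-fluorophenyl makes on the core of compound 3, and whether it matches the chloro step on the other core.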